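Aziridinyl quinone series: side chain swap on compound 1

A few compounds are considered here, and "the series" means these few. Any claim that something is new, unique, unknown or untested is made for them only; others in the source may bear on it.

Three compounds of the shared core have numbers in a functional assay on L1210 cells (Mus musculus), with a stated time of 1 days; a lower number here means a less potent compound, a higher number a more potent compound, by a factor of ten per unit of this negative logarithm. Compound 1 `CC1=C(N2CC2)C(=O)C(Cc2ccccc2)=C(N2CC2)C1=O` gives 4.74, the lowest of the three. Compound 3 `CCCC1=C(N2CC2)C(=O)C(CCOC(N)=O)=C(N2CC2)C1=O` gives 4.9, a number within the scatter of that of compound 1, so the two are not separated. Compound 2 `CCC(COC(N)=O)C1=C(N2CC2)C(=O)C(C)=C(N2CC2)C1=O` gives 6.03, which lies beyond the scatter above compound 1 and is the furthest of the three from it.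

The next compound, compound 4 `COC(CO)C1=C(N2CC2)C(=O)C(C)=C(N2CC2)C1=O`, differs from compound 1 in one place: 2-hydroxy-1-methoxyethyl in place of benzyl on a double-bonded ring carbon. Within the data shown here, no pair of measured compounds differing in one place is available to calibrate this kind of change, so the expectation rests on the values alone.

The number for compound 4 is expected to rise, because compound 2, which also carries a methyl on the core with a polar side chain, gives 6.03 while compound 1 gives 4.74. The estimated step is a number 0.76 log units higher from compound 1 to compound 4 (beyond the scatter). Compound 4 is estimated at 5.5, within a range from 4.8 to 6.2.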

Compound 4, logarithm of the reciprocal of the active concentration, log(1/C): 6.05
Beside the measured number, compound 4's estimate is 0.55 log units below it; the measured number falls inside the stated range.
By their numbers in this assay, from the lowest: compounds 1 and 3 (each within the scatter of the next); then compounds 2 and 4 (each within the scatter of the next).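

Among these compounds, this is the first one-place step: on a double-bonded ring carbon of the shared core, replacing benzyl with 2-hydroxy-1-methoxyethyl gives a number 1.31 log units higher from compound 1 to compound 4 (beyond the scatter) in this assay. The number at this position therefore responds strongly to the side chain, and a chain with no ring and with oxygen atoms is compatible with a high value here. Compound 4 gives 6.05 and compound 2 gives 6.03, within the scatter of each other, while no evidence on why the number rises is available.

Among the compounds shown here, the single step changes the ring, the size and the oxygen content together, so it leaves open which of these goes with the rise. A pentyl chain or a 2-hydroxyethyl group at this carbon would begin to separate them.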